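The source may hold more compounds than are shown below. What is called first, only, known or untested is meant among the compounds shown, and "the series" means these compounds.

Measured in a functional assay on HepG2 cells (Homo sapiens) for cytotoxicity, read by MTT assay, with a stated time of 72 h (on this read-out higher numbers stand for weaker inhibition and lower numbers for stronger inhibition), so far:
compound 1 `O=C(NCCCn1ccnc1)c1cc2ccccc2s1` gives 5200 nM
compound 2 `Cc1ccsc1C(=O)NCCCn1ccnc1` gives 102000 nM
compound 3 `Cc1ccc(C(=O)NCCCn2ccnc2)s1` gives 3900 nM

Compound 3, at 3900 nM on this assay, has the lowest of the three numbers, though its gap to compound 1 lies within the scatter, so the two cannot be ranked. Compound 2 stands apart, with a number higher than that of compound 3 by a margin well beyond the scatter.

The next compound is compound 4 `O=C(NCCCn1ccnc1)c1ccc([N+](=O)[O-])s1`, which has nitro in place of methyl on an aromatic carbon of compound 3. The site lies next to the ring sulfur and two ring bonds from the ring atom that bears a large group. The count for this change is nitro in place of methyl on an aromatic carbon in full.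

Within the data shown here, no two measured compounds differ in one place only, so the data give no direct size for such a step. Compound 1 at 5200 nM and compound 3 at 3900 nM agree despite their different cores, while compound 2 at 102000 nM shows that the number can still move far. No step beyond the scatter is expected, and the estimated result is a 1.3-fold lower number from compound 3 to compound 4 (0.11 log units; within the scatter) on this reading, with a wide margin on either side. Compound 4 is estimated at 3000 nM with an expected range from 700 nM to 14000 nM for the measurement.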

Compound 4, half-maximal inhibitory concentration: 60000 nM
The estimate for compound 4 lay 20-fold (1.30 log units) below the measured number; the measured number lies above the stated range.
By their numbers in this assay, from the lowest: compounds 3 and 1 (each within the scatter of the next); then compounds 4 and 2 (each within the scatter of the next).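

In this assay the change to nitro in place of methyl on an aromatic carbon, at the site next to the ring sulfur and two ring bonds from the ring atom that bears a large group, gives a 15-fold higher number from compound 3 to compound 4 (1.19 log units; beyond the scatter) as the first step read between two compounds that differ in one place. It shows that this position is not indifferent on this read-out: exchanging this one group, with the rest of the molecule unchanged, is enough to carry the number well beyond the scatter, and the move is towards weaker inhibition. Nothing measured alongside these numbers bears on why the step is this large, so its origin stays unexplained.

Going by these compounds, a single step cannot tell whether the size of this move belongs to nitro in particular or would follow from losing methyl with almost any replacement, so how the number would respond to an amine, a carboxylic acid or a chlorine atom at this site stays open. On these data alone, it also stays open whether nitro would move the number as far on the core of compound 1.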